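This account rests on a few compounds, and the source may have more. Where it says the series, first, only, none or still open, it means among the compounds named here.

Measured so far:
compound 1 `CN1CCc2nc(C#Cc3ccccc3)sc2C1` — in an assay on HEK293 cells for negative allosteric modulation of metabotropic glutamate receptor 5 (Homo sapiens), read by FLIPR, with a stated time of 1 h (a higher number here means a weaker inhibitor, a lower number a stronger inhibitor), compound 1 reaches only a limit, > 10000 nM.
compound 2 `CCN1CCc2nc(C#Cc3ccccc3)sc2C1` — in this assay compound 2 gives 1200 nM.

Compound 2 holds the only number shown; the other value is a limit (the limit of > 10000 nM in this assay, at which 1 of the 2 values shown sits). Compound 3 `CCCCN1CCc2nc(C#Cc3ccccc3)sc2C1` differs from compound 2 by ethyl in place of hydrogen on a saturated chain carbon, two bonds along the chain from an amine nitrogen in a ring, which read one bond further out is ethyl to butyl. Among the compounds with values here, the one measured step, an at least 8.3-fold lower number from compound 1 to compound 2 (0.92 log units; beyond the scatter), lengthened the same chain by one carbon and gave a lower number. Growing the chain further is therefore expected to lower the number again or leave it within the scatter, a 2.0-fold lower number from compound 2 to compound 3 (0.30 log units; within the scatter). Compound 3 is estimated at 600 nM, between 150 nM and 3000 nM.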

Compound 3, half-maximal inhibitory concentration: > 10000 nM
Compound 3 gave a limit, no number; the forecaster's own chance of this, stated with the estimate: 5%; middle value at least 16-fold (1.22 log units) away from the limit.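

Growing the chain on the amine nitrogen in a ring does not keep lowering the number: ethyl to butyl gives an at least 8.3-fold higher number from compound 2 to compound 3 (0.92 log units; beyond the scatter) and so reverses the direction of the earlier step. In this assay, only the ethyl of compound 2 gives a number among these compounds. Compound 1 and compound 3 both end at a limit, so the step between them cannot be read: the limit of > 10000 nM in this assay, at which 2 of the 3 values shown sit.

Going by these compounds, it stays open whether a propyl group on that nitrogen gives a number, and whether a cyclopropylmethyl group or a chain ending in a hydroxyl group behaves like ethyl or like butyl.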